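Dichlorophenyl Urea: Expected Cytotoxicity in Nasopharyngeal Cells

The source may report more compounds than this note shows. Statements on the series, on what has been measured and on what is new or still open speak of the compounds shown alone.

Three diaryl ureas built on the same dimethylpyrimidine-linked core have been tested in a functional assay on CNE-2 cells (Homo sapiens) for cytotoxicity, read by MTT assay, with a stated time of 3 days; on this read-out higher numbers stand for weaker inhibition and lower numbers for stronger inhibition. Compound 1 `Cc1cc(C)nc(Oc2ccc(NC(=O)Nc3ccc(OC(F)(F)F)cc3)cc2)n1` gives 30800 nM. Compound 3 `Cc1cc(C)nc(Sc2ccc(NC(=O)Nc3ccc(OC(F)(F)F)cc3)cc2)n1` gives 22800 nM. Compound 2 `Cc1cc(C)nc(Sc2ccc(NC(=O)Nc3ccccc3)cc2)n1` gives 22000 nM, the lowest of the three numbers, though its gaps to compound 3 and to compound 1 both lie within the scatter, so no order among the three can be claimed.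

The next compound, compound 4 `Cc1cc(C)nc(Sc2ccc(NC(=O)Nc3ccc(Cl)cc3Cl)cc2)n1`, has not been measured. It differs from compound 2 in one place: 2,4-dichlorophenyl in place of phenyl on an amide-type nitrogen. Among the measured compounds shown here, no measured pair carries chlorine on that terminal ring, so the change itself has no direct precedent. The closest comparison is the change on the same terminal ring, a 1.0-fold higher number from compound 2 to compound 3 (0.02 log units; within the scatter), which shows that a group added to that ring left this assay unmoved. The other known step, a 1.4-fold lower number from compound 1 to compound 3 (0.13 log units; within the scatter), concerns the linker and also stayed within the scatter. Both steps point to a series in which single changes have so far produced nothing beyond noise, and the estimate for compound 4 follows that: a 1.4-fold lower number from compound 2 to compound 4 (0.14 log units; within the scatter) is expected. Compound 4 is therefore estimated at 16000 nM, within a range from 6000 nM to 40000 nM.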

Compound 4, half-maximal inhibitory concentration: 23200 nM
The estimate for compound 4 lay 1.5-fold (0.16 log units) below the measured number; the measured number falls inside the stated range.
By their numbers in this assay, from the lowest: compounds 2, 3, 4 and 1 (each within the scatter of the next).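

The terminal ring on the amide-type nitrogen now has a second substituted example: in this assay, 2,4-dichlorophenyl in place of phenyl gives a 1.1-fold higher number from compound 2 to compound 4 (0.02 log units; within the scatter). Until now, this ring's only example was the trifluoromethoxy change, a 1.0-fold higher number from compound 2 to compound 3 (0.02 log units; within the scatter), so a single substituent could have been a special case. With two chlorine atoms also staying within the scatter, compounds 2, 3 and 4 show that this ring accepts two different substitution patterns with no separation in this cytotoxicity read-out, and none of these three goes against that; nothing available explains this result.

From the compounds shown here alone, it remains open whether the same holds for groups of another kind on that ring, such as an amine, a carboxylic acid or a longer alkyl chain, or for a single chlorine. Going by these compounds, it is also open whether 2,4-dichlorophenyl would behave the same way with the (4,6-dimethylpyrimidin-2-yl)oxy link of compound 1, and whether any change can move the number beyond the scatter.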